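Fluoro on the Benzyl Group Across Two Dihalogenated Cores

A few compounds are considered here, and "the series" means these few. Any claim that something is new, unique, unknown or untested is made for them only; others in the source may bear on it.

The measured compounds in this set are:
Compound 1, `O=[N+]([O-])c1cc(C(F)(F)F)cc([N+](=O)[O-])c1Oc1c(Cl)cc(Cl)cc1/C=N\OCc1ccccc1`, with 1210 nM
Compound 2, `O=[N+]([O-])c1cc(C(F)(F)F)cc([N+](=O)[O-])c1Oc1c(Cl)cc(Cl)cc1/C=N\OCc1ccccc1F`, with 800 nM
Compound 3, `O=[N+]([O-])c1cc(C(F)(F)F)cc([N+](=O)[O-])c1Oc1c(Br)cc(Br)cc1/C=N\OCc1ccccc1`, with 1830 nM

All three were tested in a functional assay on MCF7 cells (Homo sapiens) for antiproliferative activity, read by MTT assay, with a stated time of 48 h; a lower number here means a stronger inhibitor, a higher number a weaker inhibitor. Compound 1 and compound 2 share one core and differ by fluoro in place of hydrogen on an aromatic carbon. This change gave a 1.5-fold lower number from compound 1 to compound 2 (0.18 log units; within the scatter), so the two numbers cannot be told apart with confidence. Compound 3 carries a different core; the difference between the core of compound 1 and the core of compound 3 is not broken down here. In this assay compound 3 gives a number close to that of compound 1, the two lying within the usual scatter, while compound 3 gives a clearly higher number than compound 2.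

Compound 4, `O=[N+]([O-])c1cc(C(F)(F)F)cc([N+](=O)[O-])c1Oc1c(Br)cc(Br)cc1/C=N\OCc1ccccc1F`, has not yet been measured. It stands to compound 3 as compound 2 stands to compound 1: it differs by fluoro in place of hydrogen on an aromatic carbon, the same change, at the same kind of place, as seen between compound 1 and compound 2. Since that change produced only a small step in this assay, compound 4 is expected to show a similarly small step, a 1.5-fold lower number from compound 3 to compound 4 (0.17 log units; within the scatter), resting on the earlier 1.5-fold lower number from compound 1 to compound 2 (0.18 log units; within the scatter). Compound 4 is therefore estimated at 1250 nM, with a likely range from 650 nM to 2400 nM.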

Compound 4, half-maximal inhibitory concentration: 880 nM
Compound 4: middle estimate off by 1.4-fold (0.15 log units), on the high side, within the range that was stated.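

In this assay, the change from benzyl to 2-fluorobenzyl gave a 2.1-fold lower number from compound 3 to compound 4 (0.32 log units; beyond the scatter), a modest step. Set beside the same change on the other core, the new step points the same way, and the two steps cannot be told apart, so in this small set the change carries from one core to the other without a detectable difference in size: the same change on two cores in this assay, a 1.5-fold lower number (0.18 log units; within the scatter) from compound 1 to compound 2 and a 2.1-fold lower number (0.32 log units; beyond the scatter) from compound 3 to compound 4, 1.4-fold (0.14 log units) apart, within the scatter of two such steps This does not show that the change has a fixed effect across the series, since it rests on only two matched pairs, one of whose steps lies within the scatter, and it does not show that either core responds more strongly than the other.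

The compounds shown leave open how the numbers would respond if chloro, methoxy or an amine stood in place of the fluoro, or if a longer chain stood in place of the benzyl group. They also leave open whether the step would hold on a core bearing methyl groups in place of the halogens, and whether it would appear in any read-out other than this assay.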